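The source may report more compounds than this note shows. Statements on the series, on what has been measured and on what is new or still open speak of the compounds shown alone.

Compound 1, `CCN(CC)S(=O)(=O)c1ccc(S(=O)(=O)N2CCC[C@@H](C(=O)N[C@H]3CC[C@H](OC)CC3)C2)cc1`: in a functional assay on MIA PaCa-2 cells (Homo sapiens) for inhibition, read by MTT assay, with a stated time of 3 days (on this read-out higher numbers stand for weaker inhibition and lower numbers for stronger inhibition), compound 1 gives 2290 nM.
Compound 2, `CCN(CC)S(=O)(=O)c1ccc(S(=O)(=O)N2CCC[C@@H](C(=O)N[C@H]3CC[C@@H](OC)CC3)C2)cc1`: in this assay compound 2 gives 590 nM.
Compound 3, `CCN(CC)S(=O)(=O)c1ccc(S(=O)(=O)N2CCC[C@@H](C(=O)N[C@@H]3CCOC3)C2)cc1`: in this assay compound 3 gives 100 nM.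

Compound 3 stands lowest of the three. The step of a 5.9-fold lower number from compound 2 to compound 3 (0.77 log units; beyond the scatter) and the step of a 23-fold lower number from compound 1 to compound 3 (1.36 log units; beyond the scatter) both come from putting oxolan-3-yl in place of 4-methoxycyclohexyl on the amide-type nitrogen, while the step of a 3.9-fold lower number from compound 1 to compound 2 (0.59 log units; beyond the scatter) arises because of the fact that compounds 1 and 2 differ only in the configuration as drawn. Compound 4, `CCN(CC)S(=O)(=O)c1ccc(S(=O)(=O)N2CCC[C@@H](C(=O)N3CC[C@@H](OC)C3)C2)cc1`, differs from compound 3 by 3-methoxypyrrolidin-1-yl in place of (oxolan-3-yl)amino on a carbonyl carbon; the hydrogen on the amide nitrogen is no longer present. Going by the values given here, none of the measured steps makes this kind of change: the two that touch the amide nitrogen only exchange the carbon group carried on it, and those gave modest to large steps. Without a direct precedent, a move in either direction beyond the scatter remains possible, and the estimate leans toward a somewhat higher number. Compound 4 is expected to give about 300 nM in this assay, with a range from 60 nM to 1500 nM. That corresponds to an expected step of a 3.0-fold higher number from compound 3 to compound 4 (0.48 log units; beyond the scatter).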

Compound 4, half-maximal inhibitory concentration: 1070 nM
Estimate against measurement, compound 4: 3.6-fold (0.55 log units) below, within the range that was stated.
By their numbers in this assay, from the lowest: compound 3; then compounds 2 and 4 (each within the scatter of the next); then compound 1.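

In this assay, 3-methoxypyrrolidin-1-yl on the carbonyl carbon, which leaves no amide hydrogen, gives an 11-fold higher number from compound 3 to compound 4 (1.03 log units; beyond the scatter) and is the first step shown that alters the amide nitrogen itself rather than only the carbon group on it. Set against (4-methoxycyclohexyl)amino, the same group gives a 1.8-fold higher number from compound 2 to compound 4 (0.26 log units; within the scatter) and a 2.1-fold lower number from compound 1 to compound 4 (0.33 log units; beyond the scatter), so the outcome of this change depends on which group leaves and on its configuration as drawn. Nothing measured here accounts for these steps.

The compounds shown do not separate the loss of the amide hydrogen from the change of ring, as none alters one without the other. Also open, going by these compounds, is how morpholin-4-yl, dimethylamino or unsubstituted pyrrolidin-1-yl would fare on the same carbonyl carbon.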